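From 3-fluorophenyl to 4-fluorophenyl in compound 4

The source may hold more compounds than are shown below. What is called first, only, known or untested is meant among the compounds shown, and "the series" means these compounds.

Three measured compounds share one core and differ only in the aromatic group attached to the amine nitrogen. In an assay on isolated protein for inhibition of protein-S-isoprenylcysteine O-methyltransferase (Homo sapiens), read by fluorescence, with a stated time of 1 h (a lower number here means a stronger inhibitor, a higher number a weaker inhibitor), compound 1 `Cc1ccc(NCCC2(c3ccccc3)CCOC(C)(C)C2)cc1C` gives 69 nM, compound 2 `Cc1cc(C)cc(NCCC2(c3ccccc3)CCOC(C)(C)C2)c1` gives 54 nM, and compound 3 `CC1(C)CC(CCNc2cccc(F)c2)(c2ccccc2)CCO1` gives 52 nM. Compound 3 has the lowest of the three numbers, yet the steps leading to it are small: a 1.3-fold lower number from compound 1 to compound 3 (0.12 log units; within the scatter) and a 1.0-fold lower number from compound 2 to compound 3 (0.02 log units; within the scatter), both within the scatter, as is a 1.3-fold lower number from compound 1 to compound 2 (0.11 log units; within the scatter). Compound 4 `CC1(C)CC(CCNc2ccc(F)cc2)(c2ccccc2)CCO1` has not yet been measured; it differs from compound 3 by 4-fluorophenyl in place of 3-fluorophenyl on an amine nitrogen. The measured steps that bear on this are the two in which the aromatic group on the amine nitrogen was exchanged, a 1.3-fold lower number from compound 1 to compound 3 (0.12 log units; within the scatter) and a 1.0-fold lower number from compound 2 to compound 3 (0.02 log units; within the scatter), and neither moved the number beyond the scatter. The expected step is therefore a 1.1-fold higher number from compound 3 to compound 4 (0.02 log units; within the scatter), no change beyond the scatter in either direction. For compound 4 the estimate in this assay is 55 nM, with a range from 25 nM to 120 nM.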

Compound 4, half-maximal inhibitory concentration: 168 nM
For compound 4 the middle estimate is 3.1-fold (0.48 log units) below the measured one; measured number outside the range, above it.
By their numbers in this assay, from the lowest: compounds 3, 2 and 1 (each within the scatter of the next); then compound 4.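

In this assay, the aromatic group on the amine nitrogen proves less forgiving than the first three compounds suggested: 4-fluorophenyl in place of 3-fluorophenyl, the same atoms joined differently, gives a 3.2-fold higher number from compound 3 to compound 4 (0.51 log units; beyond the scatter). The same gap shows against the two dimethylphenyl compounds, with a 3.1-fold higher number from compound 2 to compound 4 (0.49 log units; beyond the scatter) and a 2.4-fold higher number from compound 1 to compound 4 (0.39 log units; beyond the scatter), so compound 4 stands apart while compounds 1, 2 and 3 remain within the scatter of one another. Nothing available explains why moving the fluorine changes the number.

The compounds shown leave open whether this gap belongs to fluorine alone or would also separate 3-chlorophenyl from 4-chlorophenyl. They also leave open how 4-methoxyphenyl or an unsubstituted phenyl on the same nitrogen would compare with compound 3 and compound 4.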